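Swapping the benzyl substituent: trifluoromethyl out, chlorine in

A few compounds are considered here, and "the series" means these few. Any claim that something is new, unique, unknown or untested is made for them only; others in the source may bear on it.

Of the compounds shown here, two of a shared core have been measured in an ADME assay on microsomes from liver (Homo sapiens) for metabolic stability, read by LC-MS, using NADPH, tested at 5 uM; a higher number here means that the compound lasts longer, a lower number that the compound disappears faster. Compound 1 `Cc1cccc(CSc2cc(Cl)c(C)cc2S(=O)(=O)/N=C(\N)n2nc(C)cc2-c2ccccc2)c1` gives 0.214 h, and compound 2 `Cc1cc(-c2ccccc2)n(/C(N)=N/S(=O)(=O)c2cc(C)c(Cl)cc2SCc2cccc(C(F)(F)F)c2)n1` gives 0.169 h. Among the compounds with values here, the one step between them, a 1.3-fold lower number from compound 1 to compound 2 (0.10 log units; within the scatter), comes from putting trifluoromethyl in place of methyl on an aromatic carbon, so compound 2 sits at a number that cannot be told apart from that of compound 1, and no compound so far stands clearly apart from the other.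

Compound 3 `Cc1cc(-c2ccccc2)n(/C(N)=N/S(=O)(=O)c2cc(C)c(Cl)cc2SCc2ccc(Cl)cc2)n1` is the next compound and differs from compound 2 in a single place: 4-chlorophenyl in place of 3-(trifluoromethyl)phenyl on a saturated chain carbon bound to a sulfur

Within the data shown here, no measured step involves a chlorophenyl group, so the only guide is the step above, which swapped one group on this same benzyl ring for another and stayed within the scatter. The change to compound 3 is therefore expected to bring no step beyond the scatter in this assay, with a 1.2-fold higher number from compound 2 to compound 3 (0.07 log units; within the scatter) as the expected movement. Compound 3 is thus estimated at 0.2 h, within a range from 0.1 h to 0.4 h.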

Compound 3, half-life: 0.24 h
Estimate against measurement, compound 3: 1.2-fold (0.08 log units) below; low and high end bracket the measured number.
By their numbers in this assay, from the lowest: compounds 2, 1 and 3 (each within the scatter of the next).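

In this assay, the exchange of groups on the saturated chain carbon bound to a sulfur gives a 1.4-fold higher number from compound 2 to compound 3 (0.15 log units; within the scatter), and the matching comparison with the methyl-bearing compound gives a 1.1-fold higher number from compound 1 to compound 3 (0.05 log units; within the scatter). Both steps stay within the scatter, so 4-chlorophenyl cannot be told apart from either 3-(trifluoromethyl)phenyl or 3-methylphenyl here, and this now holds for three different aryl groups rather than two, including one whose substituent has a different name and place on the ring. There is no supporting measurement that could say what lies behind this lack of separation.

What the three compounds cannot show is whether this place is insensitive to every change or only to these aryl groups, since a benzyl ring bearing an amine or a carboxylic acid, or a longer chain between the sulfur and the ring, could still give a step beyond the scatter. From the compounds shown here alone, the shared core is also the same in all three, so it remains open whether a change elsewhere in the core would move the half-life more than any exchange at this place has so far.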